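The source may report more compounds than this note shows. Statements on the series, on what has been measured and on what is new or still open speak of the compounds shown alone.

Of the compounds shown here, three have been measured in an assay on HEK293 cells for inhibition of Voltage-dependent T-type calcium channel subunit alpha-1G (Homo sapiens); a higher number here means a weaker inhibitor, a lower number a stronger inhibitor. Compound 1 `COC(=O)c1coc(CN2CCN(C(=O)CC(c3ccc(F)cc3)c3ccc(Cl)cc3)CC2)n1` gives 8800 nM, compound 2 `COC(=O)c1coc(CN2CCN(C(=O)CC(c3ccccc3)c3ccc(C(F)(F)F)cc3)CC2)n1` gives 17100 nM, and compound 3 `Cc1ccc2nc(CN3CCN(C(=O)CC(c4ccccc4)c4ccc(F)cc4)CC3)oc2c1` gives 1290 nM, the lowest of the three numbers; its gaps to compound 1 and to compound 2 are both beyond the scatter, so compound 3 is the strongest inhibitor of the three. Compound 4 `COc1ccc(C(CC(=O)N2CCN(Cc3nc4ccc(C)cc4o3)CC2)c2ccccc2)cc1` has not yet been measured. It differs from compound 3 in one place: methoxy in place of fluoro on an aromatic carbon. Within the data shown here, no pair of measured compounds isolates this change, so there is nothing to scale the expectation by. A shift no larger than the usual scatter is expected, in either direction, with the estimated step of a 1.2-fold higher number from compound 3 to compound 4 (0.09 log units; within the scatter). Compound 4 is expected to give about 1600 nM in this assay, within a range from 600 nM to 4500 nM.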

Compound 4, half-maximal inhibitory concentration: 2480 nM
The estimate for compound 4 lay 1.6-fold (0.19 log units) below the measured number; measured number inside the range.
By their numbers in this assay, from the lowest: compounds 3 and 4 (each within the scatter of the next); then compounds 1 and 2 (each within the scatter of the next).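

Among these compounds, replacing 4-fluorophenyl with 4-methoxyphenyl gives a 1.9-fold higher number from compound 3 to compound 4 (0.28 log units; within the scatter) in this assay and is the first single change that can be read in this set. This position, para to a large group, therefore holds either fluoro or the larger methoxy, which brings a hydrogen-bond acceptor, with no difference that stands clear of the scatter. Nothing measured here bears on why the two groups read alike.

On these data alone, whether an amine, a carboxylic acid or a longer chain such as ethoxy would fit here as well stays open. So does whether the same change would read alike on the core of compound 1.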